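From 2-fluorophenyl to 4-fluorophenyl on a shared core

The source may hold more compounds than are shown below. What is called first, only, known or untested is meant among the compounds shown, and "the series" means these compounds.

In a functional assay on SGC-7901 cells (Homo sapiens) for inhibition, read by MTT assay, with a stated time of 24 h (on this read-out lower numbers stand for stronger inhibition and higher numbers for weaker inhibition), compound 1 (`CC1(C)[C@H]2CC[C@]1(C)N(Cc1cn(-c3ccccc3Br)nn1)C(=O)C2`) gives 500 nM while compound 2 (`CC1(C)[C@H]2CC[C@]1(C)N(Cc1cn(-c3cccc(C#N)c3)nn1)C(=O)C2`) gives 250 nM and compound 3 (`CC1(C)[C@H]2CC[C@]1(C)N(Cc1cn(-c3ccccc3F)nn1)C(=O)C2`) gives 300 nM so compound 3 sits within the scatter of both others. Compound 4 (`CC1(C)[C@H]2CC[C@]1(C)N(Cc1cn(-c3ccc(F)cc3)nn1)C(=O)C2`) carries 4-fluorophenyl in place of 2-fluorophenyl on an aromatic nitrogen and has the same atoms as compound 3, joined differently. Among the measured compounds shown here, no measured step makes this exact change. The closest evidence is a 1.7-fold lower number from compound 1 to compound 3 (0.22 log units; within the scatter) and a 1.2-fold higher number from compound 2 to compound 3 (0.08 log units; within the scatter) and a 2.0-fold lower number from compound 1 to compound 2 (0.30 log units; within the scatter) and each of these lies within the scatter. In this assay the expected result is therefore no change at the digits printed from compound 3 to compound 4 (within the scatter) which means no step beyond the scatter. Compound 4 is estimated at 300 nM and expected to fall between 140 nM and 650 nM in repeat measurements.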

Compound 4, half-maximal inhibitory concentration: 500 nM
Beside the measured number, compound 4's estimate is 1.7-fold (0.22 log units) below it, and the stated range covers the measured number.
By their numbers in this assay, from the lowest: compounds 2, 3, 1 and 4 (each within the scatter of the next).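

In this assay, the place of the fluorine on this phenyl group can now be read directly: 4-fluorophenyl in place of 2-fluorophenyl gives a 1.7-fold higher number from compound 3 to compound 4 (0.22 log units; within the scatter) and so does not separate the two. The other comparisons agree, with a 2.0-fold higher number from compound 2 to compound 4 (0.30 log units; within the scatter) and no change at the digits printed from compound 1 to compound 4 (within the scatter), so all four groups on this aromatic nitrogen remain indistinguishable on this read-out. Nothing available explains these numbers.

Still open, on these data alone, is whether an amine or a carboxylic acid in place of the fluorine would give a step beyond the scatter.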